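Methyl addition on a furan series and a benzene series

A few compounds are considered here, and "the series" means these few. Any claim that something is new, unique, unknown or untested is made for them only; others in the source may bear on it.

The study covers four compounds that share an unsaturated amide chain carried on an aromatic core. Compound 1 has the structure `C/C(=C\c1cc(-c2ccccc2)co1)C(N)=O` and compound 2 the structure `C/C(=C\c1cc(-c2ccc(C)cc2)co1)C(N)=O`; the pair differ only in that (methyl in place of hydrogen on an aromatic carbon). Compound 3 has the structure `C/C(=C\c1cccc(-c2ccccc2)c1)C(N)=O`, and compound 4, which is the one not yet measured, has the structure `C/C(=C\c1cccc(-c2ccc(C)cc2)c1)C(N)=O`; between them the same change is made, namely (methyl in place of hydrogen on an aromatic carbon). The difference between the core of compound 1 and the core of compound 3 is not broken down here.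

In a functional assay on T-24 cells (Homo sapiens) for cytotoxicity, read by CCK-8 assay, with a stated time of 24 h (a lower number here means a stronger inhibitor, a higher number a weaker inhibitor), compound 1 reaches only the limit of the assay, at > 50000 nM. In this assay compound 2 likewise reaches only the limit, at > 50000 nM. For compound 3 this assay again gives only the limit, at > 50000 nM. Because of the limit of > 50000 nM in this assay, at which 3 of the 3 values shown sit, the step that the two limits leave unreadable from compound 1 to compound 2 cannot be sized, since both of its ends are limits rather than numbers.

The step from compound 3 to compound 4 is therefore expected to be just as unreadable, since its starting point in this assay is itself a limit; the expected value of that step is written as a step that the limit leaves unreadable from compound 3 to compound 4. Compound 4 is accordingly expected to give a value near 80000 nM in this assay, most probably as a further limit. The expected range for compound 4 runs from 30000 nM to 300000 nM.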

Compound 4, half-maximal inhibitory concentration: 7650 nM
Compound 4: middle estimate off by 10-fold (1.02 log units), on the high side; measured number outside the range, below it.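

In this assay, methyl in place of hydrogen, para to a large group on the six-membered aromatic ring of carbon only, gives an at least 6.5-fold lower number from compound 3 to compound 4 (0.81 log units; beyond the scatter), a step beyond the scatter whose true size may be larger, as its starting point is a limit. For the compounds shown here, the same change on the core of compound 1 cannot be sized, because both of its ends are limits rather than numbers, so the two cores offer no pair of sizes to set side by side: the limit of > 50000 nM in this assay, at which 3 of the 4 values shown sit. Thus the change is seen to lower the number on the core of compound 3 only; this does not show that the core of compound 1 fails to respond, nor that the step carries over from one core to the other, and two pairs could not establish a rule in either case.

The compounds shown leave open whether ethyl, an amine or a carboxylic acid in the same place would give a readable number on either core. They also leave open whether the effect belongs to methyl at this place alone, and how far compound 3 truly lies from compound 4.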